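This account rests on a few compounds, and the source may have more. Where it says the series, first, only, none or still open, it means among the compounds named here.

In an ADME assay on cells (Mus musculus, strain BALB/c) for cytotoxicity, read by MTT assay, with a stated time of 24 h (on this read-out lower numbers stand for higher toxicity in this test and higher numbers for lower toxicity in this test), compound 3 `COc1cc(-c2nnc(SCc3ccccc3Cl)o2)ccc1O` gives 564000 nM, the highest of the three numbers recorded so far; compound 2 `COc1cc(-c2nnc(SCc3ccccc3Br)o2)ccc1O` gives 363000 nM and compound 1 `COc1cc(-c2nnc(SCc3ccccc3[N+](=O)[O-])o2)ccc1O` gives 331000 nM. The gaps between them are small: a 1.6-fold higher number from compound 2 to compound 3 (0.19 log units; within the scatter) and a 1.7-fold higher number from compound 1 to compound 3 (0.23 log units; within the scatter) both stay within the scatter, as does a 1.1-fold higher number from compound 1 to compound 2 (0.04 log units; within the scatter), so none of the three can be set apart from the others on these figures. Compound 4 `COc1cc(-c2nnc(SCc3ccccc3C)o2)ccc1O` differs from compound 3 by a single change: methyl in place of chloro on an aromatic carbon. Among the measured compounds shown here, no measured compound carries a methyl at that place, so the steps that bear on it are the exchanges already made at the same aromatic carbon, chloro for bromo and chloro for nitro, and each of those remained within the scatter. Three rather different groups at that position have left this assay essentially flat, which gives no ground to expect that methyl will shift it beyond the scatter in either direction. On that basis compound 4 is expected to give about 500000 nM, somewhere between 250000 nM and 1000000 nM. The step this estimate implies, a 1.1-fold lower number from compound 3 to compound 4 (0.05 log units; within the scatter), is expected to amount to nothing beyond the scatter.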

Compound 4, half-maximal cytotoxic concentration: 592000 nM
Estimate against measurement, compound 4: 1.2-fold (0.07 log units) below; low and high end bracket the measured number.
By their numbers in this assay, from the lowest: compounds 1, 2, 3 and 4 (each within the scatter of the next).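

Read through this assay, methyl now joins nitro, bromo and chloro on this aromatic carbon, and each exchange for the new group stays within the scatter (a 1.0-fold higher number from compound 3 to compound 4 (0.02 log units; within the scatter); a 1.6-fold higher number from compound 2 to compound 4 (0.21 log units; within the scatter); a 1.8-fold higher number from compound 1 to compound 4 (0.25 log units; within the scatter)). The earlier steps shown here covered only nitro, bromo and chloro, so the result extends the same flat picture to a group attached through carbon, and the 2-methylphenyl compound cannot be set apart from the other three on these figures. No evidence is at hand that would explain this flatness at this place.

The compounds shown leave open whether an amine, a carboxylic acid or a longer chain such as propyl on the same aromatic carbon would also stay within the scatter, or whether one of them would finally move this read-out. They also leave open whether a change elsewhere, on the shared core or at the sulfur-bearing link, would matter more than the exchanges seen here.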